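Closing a Dipropylamino Group into a Piperidine Ring

The source may hold more compounds than are shown below. What is called first, only, known or untested is meant among the compounds shown, and "the series" means these compounds.

Of the compounds shown here, two sharing the same core have been measured in a functional assay on MIA PaCa-2 cells (Homo sapiens) for inhibition, read by MTT assay, with a stated time of 7 days; on this read-out lower numbers stand for stronger inhibition and higher numbers for weaker inhibition. Compound 1 `CCCN(CCC)S(=O)(=O)c1ccc(S(=O)(=O)N2CCC[C@@H](C(=O)OCC)C2)cc1` gives 2300 nM in this assay, the higher of the two numbers and therefore the weaker inhibitor of the pair. Compound 2 `CCN(CC)S(=O)(=O)c1ccc(S(=O)(=O)N2CCC[C@@H](C(=O)N3CCN(c4nc(C(F)(F)F)no4)CC3)C2)cc1` gives 600 nM in this assay, a lower number by a margin that lies beyond the scatter. Compound 2 differs from compound 1 in more than one place, so nothing can be said here about which part of it accounts for that gap.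

Compound 3 `CCOC(=O)[C@@H]1CCCN(S(=O)(=O)c2ccc(S(=O)(=O)N3CCCCC3)cc2)C1` has not yet been measured. It differs from compound 1 in a single spot: piperidin-1-yl in place of dipropylamino on a sulfonyl sulfur. The rest of the molecule stays exactly as in compound 1. Among the compounds with values here, no measured pair shows this particular exchange, so there is no measured step to lean on. The change is a small one, and the expected step of no change at the digits printed from compound 1 to compound 3 (within the scatter) is none beyond the scatter. Compound 3 is therefore estimated to give about 2300 nM, with a range from 1000 nM to 5500 nM.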

Compound 3, half-maximal inhibitory concentration: 2900 nM
Compound 3: middle estimate off by 1.3-fold (0.10 log units), on the low side; the measured number falls inside the stated range.
By their numbers in this assay, from the lowest: compound 2; then compounds 1 and 3 (each within the scatter of the next).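

Exchanging dipropylamino for piperidin-1-yl on a sulfonyl sulfur gives, in this assay, a 1.3-fold higher number from compound 1 to compound 3 (0.10 log units; within the scatter), so compound 1 and compound 3 cannot be told apart on this read-out. Within the data shown here, this is the first measured single change at this spot, and it shows that tying the open group with no ring into a six-membered non-aromatic ring, with one heavy atom fewer, leaves the number inside the ordinary spread of repeat measurements while the ethyl ester end and the rest of the core stay fixed. No measurement shown here offers an explanation for this outcome.

The compounds shown leave open whether the same holds for other groups on this sulfur, such as a morpholine ring, a smaller pyrrolidine ring or a short dimethylamino group, since each could behave differently from the two groups compared here. They also leave open whether piperidin-1-yl would match an open-chain amine in the same way when the ethyl ester is replaced by the larger amide end carried by compound 2.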